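Compound 4: nitro in place of methoxy

A few compounds are considered here, and "the series" means these few. Any claim that something is new, unique, unknown or untested is made for them only; others in the source may bear on it.

Measured values (an ADME assay on J774.A1 cells (Mus musculus) for cytotoxicity, read by MTT assay, with a stated time of 48 h; a lower number here means that less compound is tolerated, a higher number that more compound is tolerated)
Compound 1 `COc1ccc(/C=C(\C)C(=O)/C=C/c2ccc([N+](=O)[O-])cc2)cc1` (30000 nM)
Compound 2 `C/C(=C\c1ccc([N+](=O)[O-])cc1)C(=O)/C=C/c1ccc([N+](=O)[O-])cc1` (43000 nM)
Compound 3 `COc1ccc(/C=C/C(=O)/C(C)=C/c2ccc(N(C)C)cc2)cc1` (34300 nM)

In (this assay) compound 3 gives (34300 nM). This value lies within the scatter of both compound 1 and compound 2, so the three numbers do not separate.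

Compound 4 `C/C(=C\c1ccc(N(C)C)cc1)C(=O)/C=C/c1ccc([N+](=O)[O-])cc1` differs from compound 3 by a single exchange, nitro in place of methoxy on an aromatic carbon, para to a large group (nitro in place of methoxy on an aromatic carbon). For the measured compounds named here, only one measured step bears on this exchange, and it stays within the scatter (a 1.4-fold higher number from compound 1 to compound 2 (0.16 log units; within the scatter)). It is thin support, since it is a single step and compound 1 and compound 3 differ elsewhere in their structures. On the strength of that step (a 1.4-fold higher number from compound 1 to compound 2 (0.16 log units; within the scatter)), no change beyond the scatter is expected in (this assay), only a small rise if any. The expected step is small (a 1.2-fold higher number from compound 3 to compound 4 (0.07 log units; within the scatter)). For compound 4 the estimated value is (40000 nM), with an expected range from (22000 nM) to (70000 nM).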

Compound 4, half-maximal cytotoxic concentration: 967000 nM
Estimate against measurement, compound 4: 24-fold (1.38 log units) below, outside the stated range (above it).
By their numbers in this assay, from the lowest: compounds 1, 3 and 2 (each within the scatter of the next); then compound 4.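

In this assay compound 4 alone carries both nitro and dimethylamino, and each single exchange that leads to it gives a large rise (a 28-fold higher number from compound 3 to compound 4 (1.45 log units; beyond the scatter)) and (a 22-fold higher number from compound 2 to compound 4 (1.35 log units; beyond the scatter)) and (a 32-fold higher number from compound 1 to compound 4 (1.51 log units; beyond the scatter)). Compound 1 carries nitro without dimethylamino and compound 3 carries dimethylamino without nitro, yet both stay within the scatter of compound 2, so the rise appears only with the two groups together. The exchange of methoxy for nitro at this place therefore does not carry over from one core to the other: the same change on two cores in this assay, a 1.4-fold higher number (0.16 log units; within the scatter) from compound 1 to compound 2 and a 28-fold higher number (1.45 log units; beyond the scatter) from compound 3 to compound 4, 20-fold (1.29 log units) apart, beyond the scatter of two such steps.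

The compounds shown leave open whether a nitrile or a carboxylic acid in place of nitro, or diethylamino in place of dimethylamino, would keep this high number. The jump also rests on compound 4 alone.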